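Replacing Methyl by Acetyl on the Ring Nitrogen

The compounds below may be only part of what the source reports. "The series", "measured", "known", "first", "only" and "open" are said of these compounds alone.

Compound 1 `CNc1cc2nc(-c3ccccc3)nn(-c3ccccc3)c-2cc1=O` is tested in a functional assay on DU-145 cells (Homo sapiens) for cytotoxicity, read by MTT assay, with a stated time of 72 h (a lower number here means a stronger inhibitor, a higher number a weaker inhibitor), and gives 980 nM. Of the three measured compounds this is the highest number. Compound 2 `CCNc1cc2nc(-c3ccccc3)nn(-c3ccccc3)c-2cc1=O` gives 220 nM in this assay, and compound 3 `O=c1cc2n(-c3ccccc3)nc(-c3ccccc3)nc-2cc1N1CCCCC1` gives 610 nM. The step of a 4.5-fold lower number from compound 1 to compound 2 (0.65 log units; beyond the scatter) lies beyond the scatter, while the step of a 1.6-fold lower number from compound 1 to compound 3 (0.21 log units; within the scatter) does not; between the other pair, a 2.8-fold higher number from compound 2 to compound 3 (0.44 log units; beyond the scatter).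

Compound 4 `CC(=O)Nc1cc2nc(-c3ccccc3)nn(-c3ccccc3)c-2cc1=O` differs from compound 1 in one place: acetyl in place of methyl on a nitrogen on an aromatic ring. Read one bond further out, the change is methylamino to acetamido. All three measured steps alter the group on that same nitrogen, so they bear on this change, yet none of them brings in an acetyl or a carbonyl. The step of a 4.5-fold lower number from compound 1 to compound 2 (0.65 log units; beyond the scatter) shows that lengthening the chain by one carbon helped modestly, whereas a 1.6-fold lower number from compound 1 to compound 3 (0.21 log units; within the scatter) stayed within the scatter, so the nitrogen tolerates several substituents but the data give no direct guide for an acetyl. The expectation for compound 4 is therefore a modest step in this assay, more likely toward a higher number than a lower one, carrying wide uncertainty. Compound 4 is estimated at 2000 nM, with a range from 600 nM to 7000 nM, which corresponds to an expected step of a 2.0-fold higher number from compound 1 to compound 4 (0.31 log units; beyond the scatter).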

Compound 4, half-maximal inhibitory concentration: > 5000 nM
Compound 4 gave a limit, no number (the forecaster's own chance of this, stated with the estimate: 10%); middle value at least 2.5-fold (0.39 log units) away from the limit.
By their numbers in this assay, from the lowest: compound 2; then compounds 3 and 1 (each within the scatter of the next). At a limit, above all of these: compound 4.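

In this assay, acetyl in place of methyl on this nitrogen moves the result the weak way, with an at least 5.1-fold higher number from compound 1 to compound 4 (0.70 log units; beyond the scatter) as the step, whereas no earlier change on this nitrogen moved the number upward beyond the scatter from compound 1. The gap also holds against the other two amine groups, as an at least 8.1-fold higher number from compound 3 to compound 4 (0.91 log units; beyond the scatter) and the large at least 22-fold higher number from compound 2 to compound 4 (1.35 log units; beyond the scatter) show, so a nitrogen that carried methylamino, ethylamino and piperidin-1-yl with measurable numbers loses that activity once it carries acetamido. Compound 4 gives a limit and not a number, so these steps mark only the smallest gaps the data allow: the limit of > 5000 nM in this assay, at which 1 of the 4 values shown sits.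

With acetamido as the only group of its kind here, the compounds shown cannot tell whether the carbonyl itself matters or only this particular acyl group, which a propionyl or a methanesulfonyl group on the same nitrogen would help to settle. Going by these compounds, it also remains open whether the gain from methylamino to ethylamino continues with a longer chain such as propylamino, or how an unsubstituted amino group would compare.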